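Working notes: from compound 2 to compound 3

The source may hold more compounds than are shown below. What is called first, only, known or untested is meant among the compounds shown, and "the series" means these compounds.

Measured in a functional assay on A549 cells (Homo sapiens) for cytotoxicity, read by MTT assay, with a stated time of 72 h; a lower number here means a stronger inhibitor, a higher number a weaker inhibitor:
- compound 1 `Cc1ccc(NC(=O)CN2CCN(c3nnc(Cc4ccncc4)c4ccccc34)CC2)c(C)c1`: 45000 nM
- compound 2 `Cc1cccc(Cl)c1NC(=O)CN1CCN(c2nnc(Cc3ccccc3)c3ccccc23)CC1`: 7420 nM

Compound 2 has the lower number of the two, which makes it the stronger inhibitor here, and its gap to compound 1 lies beyond the scatter. Going by the values given here, these two compounds differ in more than one place, so no single-place step is available to guide the next comparison.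

The unmeasured compound 3 `Cc1ccc(NC(=O)CN2CCN(c3nnc(Cc4ccccc4)c4ccccc34)CC2)c(C)c1` carries 2,4-dimethylphenyl in place of 2-chloro-6-methylphenyl on an amide-type nitrogen. Compound 1 carries the same 2,4-dimethylphenyl and gives 45000 nM. Part of its gap to compound 2 may therefore travel with this group, though the data cannot show how much. A modest rise in the number, slightly beyond the scatter, is expected, with the estimate being a 2.4-fold higher number from compound 2 to compound 3 (0.38 log units; beyond the scatter). For compound 3 the estimated value is 18000 nM, with an expected range of 7000 nM to 45000 nM.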

Compound 3, half-maximal inhibitory concentration: "not active" (no number reported)
The entry for compound 3 holds no number, and the estimate cannot be compared.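

Going by these compounds alone, compound 3 is reported as "not active" with no number, so no step from compound 2 to compound 3 can be read in this assay. The compounds shown leave open how large a change 2,4-dimethylphenyl in place of 2-chloro-6-methylphenyl brings on the shared core. No measurement at hand bears on this result.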